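The source may hold more compounds than are shown below. What is called first, only, known or untested is meant among the compounds shown, and "the series" means these compounds.

In a functional assay on MDA-MB-468 cells (Homo sapiens) for cytotoxicity, read by resazurin assay, with a stated time of 72 h (on this read-out lower numbers stand for stronger inhibition and higher numbers for weaker inhibition), compound 1 `CC1(C)OB(CCCSC(=S)NCc2cccnc2)OC1(C)C` gives 6620 nM and compound 2 `S=C(NCc1cccnc1)SCCn1nc2ccccc2n1` gives 11600 nM. Compound 3 `S=C(NCc1cccnc1)SCCc1nnc(-c2ccccc2)o1` stands at 2770 nM as the lowest of the three numbers, and its gaps to both others lie beyond the scatter. Compound 4 `S=C(NCc1cccnc1)SCCc1nnc(-c2cccs2)o1` differs from compound 3 in one place: thiophen-2-yl in place of phenyl on an aromatic carbon. This puts thiophen-2-yl in place of phenyl on an aromatic carbon. Within the data shown here, no measured pair shows such a change, so the expectation rests on compound 3 at 2770 nM and favours no firm direction in this assay. The expected step of a 1.1-fold lower number from compound 3 to compound 4 (0.04 log units; within the scatter) is small and stays within the scatter. The estimated value for compound 4 is 2500 nM, with an expected range from 1000 nM to 6500 nM.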

Compound 4, half-maximal inhibitory concentration: 3410 nM
Compound 4: middle estimate off by 1.4-fold (0.13 log units), on the low side; low and high end bracket the measured number.
By their numbers in this assay, from the lowest: compounds 3, 4, 1 and 2 (each within the scatter of the next, the first and the last beyond it).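

In this assay, thiophen-2-yl in place of phenyl on an aromatic carbon gives a 1.2-fold higher number from compound 3 to compound 4 (0.09 log units; within the scatter). Among these compounds, this is the first single-place comparison in the set, and it shows that this exchange of one aromatic ring for another, with its sulfur and one heavy atom fewer, leaves the number within the scatter at this position. Going by these compounds, whether a group other than an aromatic ring, such as an amine or a carboxylic acid, on this same carbon would move the number beyond the scatter stays open. No measurement shown here gives a reason for the result.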